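Swapping the aryl on the triazole: what compound 4 may give

A few compounds are considered here, and "the series" means these few. Any claim that something is new, unique, unknown or untested is made for them only; others in the source may bear on it.

Of the compounds shown here, three sharing one spiro core have been tested in a functional assay on MCF7 cells (Homo sapiens) for antiproliferative activity, read by MTT assay, with a stated time of 48 h; a higher number here means a weaker inhibitor, a lower number a stronger inhibitor. Compound 1 `N#CC1=C(N)Oc2c(N)cc3nc4ccccc4nc3c2C12C(=O)N(Cc1cnnn1-c1cccc(C(F)(F)F)c1)c1ccccc12` gives 31600 nM. Compound 3 `N#CC1=C(N)Oc2c(N)cc3nc4ccccc4nc3c2C12C(=O)N(Cc1cnnn1-c1cc(Cl)ccc1Cl)c1ccccc12` gives 33200 nM, a step of a 1.1-fold higher number from compound 1 to compound 3 (0.02 log units; within the scatter). Compound 2 `COc1ccc(-n2nncc2CN2C(=O)C3(C(C#N)=C(N)Oc4c(N)cc5nc6ccccc6nc5c43)c3ccccc32)cc1` reaches only the limit of the assay, > 50000 nM. Of the two compounds with a number, compound 3 has the higher figure, but its gap to compound 1 lies within the scatter, so the two cannot be ordered.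

Compound 4 `COc1cc(-n2nncc2CN2C(=O)C3(C(C#N)=C(N)Oc4c(N)cc5nc6ccccc6nc5c43)c3ccccc32)c(OC)cc1Cl` differs from compound 3 in one place: 4-chloro-2,5-dimethoxyphenyl in place of 2,5-dichlorophenyl on an aromatic nitrogen. Among the measured compounds shown here, two measured steps bear on this change, both at the same aromatic nitrogen. The step of an at least 1.5-fold lower number from compound 2 to compound 3 (0.17 log units; that floor lies within the scatter) is the closer one, since compound 4 carries methoxy groups as compound 2 does while keeping a chlorine as compound 3 does. Compound 2, whose ring bears a methoxy, reached only the limit (the limit of > 50000 nM in this assay, at which 1 of the 3 values shown sits), which leans the expectation toward a higher number than compound 3 shows. Compound 4 is therefore expected to give about 40000 nM, between 20000 nM and 80000 nM, an expected step of a 1.2-fold higher number from compound 3 to compound 4 (0.08 log units; within the scatter) in this assay, with a real chance that only a limit is reported.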

Compound 4, half-maximal inhibitory concentration: > 50000 nM
Compound 4 ended at the assay's limit (the forecaster's own chance of this, stated with the estimate: 40%); middle value at least 1.2-fold (0.09 log units) away from the limit.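

In this assay, two compounds now carry methoxy groups on the aryl ring at this aromatic nitrogen, compound 2 and compound 4, and both sit at a limit of the assay rather than at a number, so the chlorine that compound 4 shares with compound 3 does not bring a methoxy-bearing compound back to a measured figure: the limit of > 50000 nM in this assay, at which 2 of the 4 values shown sit.

Against the two compounds that do have numbers, the readable steps are an at least 1.5-fold higher number from compound 3 to compound 4 (0.17 log units; that floor lies within the scatter) and an at least 1.5-fold higher number from compound 1 to compound 4 (0.19 log units; that floor lies within the scatter), and these floors say only that compound 4 gave no number, not how far it really lies from either compound. The steps that involve compound 2 and compound 4 together cannot be read, with a limit on each side, so those two cannot be ordered.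

No step shown at this position is printed as lying beyond the scatter, so it remains open whether any aryl swap here truly changes the result in this assay. From the compounds shown here alone, it is also open whether an amine or a carboxylic acid on this aryl ring would give a clearly lower number than the chlorine and trifluoromethyl rings do.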